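This account rests on a few compounds, and the source may have more. Where it says the series, first, only, none or still open, it means among the compounds named here.

Of the compounds shown here, two of a shared core have been measured in an assay on CHO cells for agonist activity at Free fatty acid receptor 1 (Homo sapiens), read by luminescence, with a stated time of 20 s, in the presence of a further agent that is not named here; on this read-out lower numbers stand for an effect already at smaller amounts and higher numbers for an effect only at larger amounts of compound. Compound 1 `COc1ccccc1-c1cccc(COc2ccc([C@H](CC(=O)O)c3nccn3C)cc2)c1` gives 410 nM in this assay, and compound 2 `Cc1cc(Cl)ccc1-c1cc(COc2ccc([C@H](CC(=O)O)c3nccn3C)cc2)ccc1C` gives 97 nM. Of these two numbers, compound 1 holds the higher one, and the gap between them lies beyond the scatter, so compound 2 reaches its effect at smaller amounts than compound 1. Going by the values given here, no pair of compounds that differ in a single place has been measured, so no step between measured compounds is available.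

Compound 3 `Cc1cc(F)ccc1-c1cccc(COc2ccc([C@H](CC(=O)O)c3nccn3C)cc2)c1` has not yet been measured. It differs from compound 1 in one place: 4-fluoro-2-methylphenyl in place of 2-methoxyphenyl on an aromatic carbon. Compound 2 carries a related group on the same ring, a 4-chloro-2-methylphenyl, together with a further methyl on the central ring, so the change toward compound 3 moves part of the way from compound 1 toward compound 2.

On this basis, a step of moderate size toward a lower number is expected from compound 1 to compound 3, a 2.1-fold lower number from compound 1 to compound 3 (0.31 log units; beyond the scatter). Compound 3 is estimated to give 200 nM in this assay, with a range from 80 nM to 500 nM.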

Compound 3, half-maximal effective concentration: 59 nM
For compound 3 the middle estimate is 3.4-fold (0.53 log units) above the measured one; measured number below the stated range.
By their numbers in this assay, from the lowest: compounds 3 and 2 (each within the scatter of the next); then compound 1.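

In this assay, placing 4-fluoro-2-methylphenyl instead of 2-methoxyphenyl on this aromatic carbon, meta to a large group, gives a 6.9-fold lower number from compound 1 to compound 3 (0.84 log units; beyond the scatter), the first single-place step available on the shared core, and it shows that the group held at this position affects the read-out. Both groups count the same number of heavy atoms and the same single six-membered aromatic ring, yet the entering group has no hydrogen-bond acceptor while the leaving group has one, so an acceptor on this ring is not needed for compound 3 to reach 59 nM. No measurement is at hand that accounts for the size of this step.

The change alters two features of the ring at once, the methoxy group giving way to a methyl group and a fluorine entering, so the compounds shown do not tell how much of the step belongs to each. A plain 2-methylphenyl or a 4-fluoro-2-methoxyphenyl group would separate the two, and an amine or a nitrile on the same ring would test how far this position tolerates other groups.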